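Urea series: from compound 1 to compound 3

This account rests on a few compounds, and the source may have more. Where it says the series, first, only, none or still open, it means among the compounds named here.

Compound 1 `COc1cc(NC(C)CCCNC(=O)NNC(=O)Nc2ccc(F)cc2)c2ncccc2c1`: >= 250000 nM, a limit
Compound 2 `COc1cc(NC(C)CCCNC(=O)Nc2cc(C(F)(F)F)cc(C(F)(F)F)c2)c2ncccc2c1`: 3100 nM

In a functional assay on HeLa cells (Homo sapiens) for inhibition, read by MTT assay, with a stated time of 72 h (a higher number here means a weaker inhibitor, a lower number a stronger inhibitor), compound 1 gives only a limit, >= 250000 nM, and no number. Compound 3 `COc1cc(NC(C)CCCNC(=O)Nc2ccc(C(F)(F)F)cc2)c2ncccc2c1` carries 4-(trifluoromethyl)phenyl in place of ((4-fluorophenyl)carbamoyl)amino on an amide-type nitrogen. For the measured compounds named here, with compound 2 at 3100 nM as the only true number in this assay, a large step toward stronger inhibition is expected. The estimated change is an at least 27-fold lower number from compound 1 to compound 3 (1.44 log units; beyond the scatter). Its size stays uncertain, since the starting point is a limit. Compound 3 is expected at 9000 nM, with an estimated range of 3000 nM to 35000 nM.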

Compound 3, half-maximal inhibitory concentration: 8300 nM
Estimate against measurement, compound 3: 1.1-fold (0.04 log units) above, and the stated range covers the measured number.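

In this assay placing 4-(trifluoromethyl)phenyl on the amide-type nitrogen in place of ((4-fluorophenyl)carbamoyl)amino gives an at least 30-fold lower number from compound 1 to compound 3 (1.47 log units; beyond the scatter) and turns a limit into a true number. The exchange removes the hydrogen-bond donors and the acceptor counted for the leaving group and changes the aryl substituent at once, so these changes cannot be separated. The size of the step is only a floor, since compound 1 stands at a limit: the limit of >= 250000 nM in this assay, at which 1 of the 3 values shown sits.

Going by these compounds, it remains open how a phenyl ring carrying only fluorine at this position would compare with compound 3. Also open, on these data alone, is what an amine or a carboxylic acid in place of trifluoromethyl would give.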